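A few compounds are considered here, and "the series" means these few. Any claim that something is new, unique, unknown or untested is made for them only; others in the source may bear on it.

Measured compounds:
compound 1 `COc1cc(/C=C2\CN(C)C/C(=C\c3cccnc3)C2=O)cc(OC)c1`, 7900 nM
compound 2 `COc1cc(/C=C2\CN(C)C/C(=C\c3ccncc3)C2=O)cc(OC)c1`, 8400 nM
compound 3 `O=C1/C(=C/c2cccnc2)CNC/C1=C\c1ccccc1C(F)(F)F`, 3800 nM

In a functional assay on QGY-7703 cells (Homo sapiens) for cytotoxicity, read by MTT assay, with a stated time of 24 h (on this read-out higher numbers stand for weaker inhibition and lower numbers for stronger inhibition), compound 1 gives 7900 nM and compound 2 gives 8400 nM. The change between them is pyridin-4-yl in place of pyridin-3-yl on a double-bonded chain carbon bound to a double-bonded ring carbon and it made a 1.1-fold higher number from compound 1 to compound 2 (0.03 log units; within the scatter). Compound 3 gives 3800 nM in this assay; the difference between its core and the core of compound 1 is not broken down here. Compound 4 `O=C1/C(=C/c2ccncc2)CNC/C1=C\c1ccccc1C(F)(F)F` has not yet been measured. It differs from compound 3 by pyridin-4-yl in place of pyridin-3-yl on a double-bonded chain carbon bound to a double-bonded ring carbon, the same change as from compound 1 to compound 2. Because the earlier step was a 1.1-fold higher number from compound 1 to compound 2 (0.03 log units; within the scatter), the step in this assay from compound 3 to compound 4 is expected to be about as small, a 1.1-fold higher number from compound 3 to compound 4 (0.04 log units; within the scatter), resting on that single pair only. Compound 4 is therefore estimated at 4200 nM, between 2000 nM and 8500 nM.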

Compound 4, half-maximal inhibitory concentration: 4900 nM
The estimate for compound 4 lay 1.2-fold (0.07 log units) below the measured number, and the stated range covers the measured number.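

In this assay, pyridin-4-yl in place of pyridin-3-yl again gives a step within the scatter, with a 1.3-fold higher number from compound 3 to compound 4 (0.11 log units; within the scatter). The change carries from one core to the other with no difference in size that can be told apart: the same change on two cores in this assay, a 1.1-fold higher number (0.03 log units; within the scatter) from compound 1 to compound 2 and a 1.3-fold higher number (0.11 log units; within the scatter) from compound 3 to compound 4, 1.2-fold (0.08 log units) apart, within the scatter of two such steps. This rests on two pairs only, so it shows that the change has little effect on the core of compound 1 and the core of compound 3, but not that it would stay as small on any other core or in any other assay.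

Still open, as far as these compounds go, is whether pyridin-2-yl or plain phenyl in the same place would also give so small a step. Also open, from the compounds shown here alone, is whether the change stays this small on a core carrying an amine or a carboxylic acid.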